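The compounds below may be only part of what the source reports. "The series", "measured", "known", "first", "only" and "open" are said of these compounds alone.

Measured compounds in an ADME assay on HepG2 2.2.15 cells (Homo sapiens) for cytotoxicity; on this read-out lower numbers stand for higher toxicity in this test and higher numbers for lower toxicity in this test:

- compound 1, `O=C(Nc1ncc(C(Oc2ccc3cc(Br)ccc3c2)c2ccc(Cl)cc2)s1)c1cccs1`, "not toxic" (no number reported)
- compound 2, `O=C(Nc1ncc(C(Oc2ccc3cc(Br)ccc3c2)c2ccc(Cl)cc2)s1)c1ccccc1`, "not toxic" (no number reported)
- compound 3, `N#Cc1cccc(C(=O)Nc2ncc(C(Oc3ccc4cc(Br)ccc4c3)c3ccc(Cl)cc3)s2)c1`, > 50000 nM

Compound 3, with the structure `N#Cc1cccc(C(=O)Nc2ncc(C(Oc3ccc4cc(Br)ccc4c3)c3ccc(Cl)cc3)s2)c1`, gives only a limit of this assay, > 50000 nM, and not a number. Within the data shown here, compound 1 and compound 2 are described as not toxic without any number reported, so no step between two measured compounds can be read from this series; the one numerical entry is a limit, (the limit of > 50000 nM in this assay, at which 1 of the 3 values shown sits).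

The next compound, compound 4, has the structure `O=C(Nc1ncc(C(Oc2ccc3cc(Br)ccc3c2)c2ccc(Cl)cc2)s1)c1ccc(Cl)nc1`. It differs from compound 3 in one place: 6-chloropyridin-3-yl in place of 3-cyanophenyl on a carbonyl carbon. Among the measured compounds shown here, with no measured step in this assay to lean on, and with compound 3 sitting at the limit, no movement beyond the scatter is expected in either direction; the step from compound 3 to compound 4 is estimated as a number no higher from compound 3 to compound 4 (the limit leaves the size open). For compound 4 the expected outcome in this assay is 50000 nM, within 20000 nM to 100000 nM, most likely reported again as a limit rather than a number.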

Compound 4, half-maximal cytotoxic concentration: "not toxic" (no number reported)
The entry for compound 4 holds no number; there is nothing to compare the estimate with.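

In this assay, among these compounds, compound 4 is entered as "not toxic" (no number reported), so no step from compound 3 to compound 4 can be read. Compound 3 gives only a limit, > 50000 nM. As far as these compounds go, whether the groups on the carbonyl carbon change the half-maximal cytotoxic concentration at all remains open.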